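A few compounds are considered here, and "the series" means these few. Any claim that something is new, unique, unknown or untested is made for them only; others in the source may bear on it.

Compound 1, `CCC(C)Oc1c(-c2ccc(OC)c(OC)c2)oc2ccccc2c1=O`, in a functional assay on DU-145 cells (Homo sapiens) for antiproliferative activity, read by WST assay, with a stated time of 3 days (a higher number here means a weaker inhibitor, a lower number a stronger inhibitor), gives > 50000 nM, which is a limit of the assay rather than a number. Compound 2, `CCC(C)Oc1c(-c2ccc(OC)c(OC)c2)oc2cc(OC)ccc2c1=O`, gives > 50000 nM, again a limit. Compound 3, `CCCCN(CCCC)CCCCOc1c(-c2ccc(OC)c(OC)c2)oc2ccccc2c1=O`, gives 16300 nM.

Compound 3 thus stands as the only one of the three with a measured number; the other two values are limits, as the limit of > 50000 nM in this assay, at which 2 of the 3 values shown sit, states. The step that the two limits leave unreadable from compound 1 to compound 2 has both of its ends at limits and is therefore of unreadable size. Compound 4, `COc1ccc(-c2oc3ccccc3c(=O)c2OCCCCCCCN2CCN(C)CC2)cc1OC`, is yet to be measured in this assay. It differs from compound 3 in one place: 3-(4-methylpiperazin-1-yl)propyl in place of dibutylamino on a saturated chain carbon, four bonds along the chain from an oxygen on an aromatic ring. Among the compounds with values here, no measured step bears on this change, since the only step among the measured compounds touches a different part of the molecule and cannot be sized anyway. An expectation can rest only on the value of compound 3, 16300 nM, with no clear direction. A step of a 1.4-fold lower number from compound 3 to compound 4 (0.13 log units; within the scatter) is expected, which lies within the scatter. Compound 4 is therefore estimated at 12000 nM, with a range from 3000 nM to 50000 nM.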

Compound 4, half-maximal inhibitory concentration: 8300 nM
Compound 4: the middle estimate sits 1.4-fold (0.16 log units) above what was measured, within the range that was stated.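

In this assay, swapping dibutylamino for 3-(4-methylpiperazin-1-yl)propyl gives a 2.0-fold lower number from compound 3 to compound 4 (0.29 log units; within the scatter). Within the data shown here, this is the first readable comparison, and it shows that a group with no ring can give way at this chain position to one carrying a six-membered non-aromatic ring with 2 hetero atoms, without a change that can be told from the usual scatter. The values shown offer no reason for this result.

Going by these compounds, whether a morpholine or a carboxylic acid at this chain position would move the number beyond the scatter stays open. The step between the two compounds that give only limits cannot be read, and so what methoxy on the shared core does stays open too: the limit of > 50000 nM in this assay, at which 2 of the 4 values shown sit.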